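The compounds below may be only part of what the source reports. "The series", "measured", "known", "first", "only" and "open" are said of these compounds alone.

Compound 1 `O=c1n(Cc2nc3nc(Cl)ccc3n2CCCCF)c2cnccc2n1C1CC1` is the reference point of the set. In an ADME assay on HeLa cells (Homo sapiens) for cytotoxicity, read by ATP content, with a stated time of 3 days (a higher number here means that more compound is tolerated, a lower number that less compound is tolerated), compound 1 reaches only a limit, > 50000 nM. Compound 2 `COc1ccc(-n2c(=O)n(Cc3cc4cc(Cl)ccc4n3CCCC#N)c3cnccc32)cc1` likewise stops at a limit in this assay, > 50000 nM. Compound 3 `N#CCCCn1c(Cn2c(=O)n(-c3ccncn3)c3ccncc32)cc2cc(Cl)ccc21` also gives no more than a limit in this assay, > 50000 nM. Going by the values given here, the only single-point step measured, a step that the two limits leave unreadable from compound 2 to compound 3, cannot be sized, and every value sits at the same place, (the limit of > 50000 nM in this assay, at which 3 of the 3 values shown sit), so no readable step exists. Compound 4 `CS(=O)(=O)CCCn1c(Cn2c(=O)n(C3CC3)c3ccncc32)nc2nc(Cl)ccc21` differs from compound 1 by methylsulfonyl in place of fluoromethyl on a saturated chain carbon, three bonds along the chain from an aromatic nitrogen. Among the compounds with values here, no measured step bears on this change, and compound 1 itself is known only as a limit, so no step beyond the scatter is expected; the expected step in this assay is a number no higher from compound 1 to compound 4 (the limit leaves the size open). Compound 4 is estimated at 50000 nM, within 20000 nM to 150000 nM, most likely again only a limit.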

Compound 4, half-maximal cytotoxic concentration: > 50000 nM
Compound 4 was reported as a limit; the forecaster's own chance of this, stated with the estimate: 80%; the middle value sits exactly at the limit.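

Compound 1 and compound 4 are both known only as limits, so no step can be read between them: the limit of > 50000 nM in this assay, at which 4 of the 4 values shown sit.
The compounds shown leave open at what concentration in this assay any of them turns cytotoxic, and what methylsulfonyl in place of fluoromethyl does to that concentration.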